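From propyl to 4-(tert-butyl)phenyl on the sulfonyl sulfur

The source may report more compounds than this note shows. Statements on the series, on what has been measured and on what is new or still open speak of the compounds shown alone.

Of the compounds shown here, two have been read so far in an ADME assay on HEK293 cells (Homo sapiens) for antiproliferative activity, read by MTT assay, with a stated time of 48 h; a higher number here means a weaker inhibitor, a lower number a stronger inhibitor: compound 1 (`O=C(/C=C/c1cn(S(=O)(=O)c2cccc3ccccc23)c2ccccc12)c1ccncc1`) and compound 2 (`CCCS(=O)(=O)n1cc(/C=C/C(=O)c2ccncc2)c2ccccc21`). Compound 1 gives > 150000 nM, which is a limit and not a number. Compound 2 gives > 150000 nM, which is also a limit. The series therefore stands as follows: the limit of > 150000 nM in this assay, at which 2 of the 2 values shown sit.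

The next step leads to compound 3 (`CC(C)(C)c1ccc(S(=O)(=O)n2cc(/C=C/C(=O)c3ccncc3)c3ccccc32)cc1`), with 4-(tert-butyl)phenyl in place of propyl on a sulfonyl sulfur. Among the measured compounds shown here, the only measured step at this place is a step that the two limits leave unreadable from compound 1 to compound 2, with propyl in place of naphthalen-1-yl. It offers no size to carry over. Compound 1 carries an aromatic ring at this place and gives > 150000 nM, a limit, so a ring here has not yet produced a readable number. No direction can be assigned in this assay, and no clear step is expected. The expected step is a number no higher from compound 2 to compound 3 (the limit leaves the size open). For compound 3 the estimated value is 150000 nM, with an expected range of 60000 nM to 300000 nM, and a report of a limit alone is the most likely outcome.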

Compound 3, half-maximal inhibitory concentration: > 150000 nM
Compound 3: only a limit was reported; the forecaster's own chance of this, stated with the estimate: 70%; the middle value sits exactly at the limit.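

In this assay compound 3 gives > 150000 nM as a limit, not a number. With compound 1 and compound 2 also reported only as limits, no step among these three compounds can be read. Still open, going by these compounds, is how naphthalen-1-yl, propyl and 4-(tert-butyl)phenyl on the sulfonyl sulfur compare in this assay and whether any group at this place gives a readable number.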